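Swapping cyclopentyl for a 3-(tert-butoxycarbonyl)propyl group

The compounds below may be only part of what the source reports. "The series", "measured", "known", "first", "only" and "open" are said of these compounds alone.

Compound 1 `NC(=O)c1c(NC(=O)Nc2ccc(Cl)cc2)sc2c1CCN(CC1CCCC1)C2`: 1830 nM
Compound 2 `CCN1CCc2c(sc(NC(=O)Nc3ccc(Cl)cc3)c2C(=O)NC)C1`: > 25000 nM

For the measured compounds named here, in a functional assay (strain AB) with Danio rerio as the target, read by microscopy, with a stated time of 1 h (a higher number here means that more compound is needed for the effect, a lower number that less compound is needed), compound 1 gives 1830 nM, the only actual number so far. Compound 2 gives only a limit, > 25000 nM. Compound 3 `CC(C)(C)OC(=O)CCCCN1CCc2c(sc(NC(=O)Nc3ccc(Cl)cc3)c2C(N)=O)C1` keeps the core of compound 1 and changes one group: 3-(tert-butoxycarbonyl)propyl in place of cyclopentyl on a saturated chain carbon bound to an amine nitrogen in a ring. Going by the values given here, no measured step shows what such a swap does, so only a modest rise in the concentration needed is expected, possibly no larger than the scatter. The expected change is a 1.9-fold higher number from compound 1 to compound 3 (0.28 log units; within the scatter). For compound 3 the estimated value is 3500 nM, with an expected range from 800 nM to 18000 nM.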

Compound 3, half-maximal effective concentration: 710 nM
Compound 3: the middle estimate sits 4.9-fold (0.69 log units) above what was measured; the measured number lies below the stated range.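

In this assay, putting 3-(tert-butoxycarbonyl)propyl in place of cyclopentyl gives a 2.6-fold lower number from compound 1 to compound 3 (0.41 log units; beyond the scatter). This place, on a saturated chain carbon bound to an amine nitrogen in a ring, therefore accepts a bigger group with no ring, and less compound is needed rather than more. Nothing shown accounts for the direction of this step.

Still open, going by these compounds, is whether the tert-butoxycarbonyl end or the chain itself matters. A carboxylic acid at the chain end, or a plain alkyl chain of the same length, would separate the two.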